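Allylamino to propoxy on the carbonyl: growth inhibition notes

The source may hold more compounds than are shown below. What is called first, only, known or untested is meant among the compounds shown, and "the series" means these compounds.

Within the data shown here, compound 2 `C=CCNC(=O)/C=C/c1ccccc1` stands lowest of the two numbers measured so far in a functional assay on the whole organism for inhibition, with Brassica rapa subsp. chinensis as the target, with a stated time of 3 days, tested at 100 ppm; on this read-out higher numbers stand for more inhibition of growth at the one concentration tested and lower numbers for less inhibition of growth: compound 2 gives 64%, while compound 1 `CC(C)(C)NC(=O)/C=C/c1ccccc1` gives 73%. Among the measured compounds shown here, the one measured step, a number 9 percentage points lower from compound 1 to compound 2 (within the scatter), lies within the scatter, so the two compounds cannot be set apart on these numbers.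

Compound 3 `CCCOC(=O)/C=C/c1ccccc1` is the next candidate and differs from compound 2 by propoxy in place of allylamino on a carbonyl carbon. For the measured compounds named here, no measured step bears on this change: the only recorded step swaps one group for another on the amide-type nitrogen and leaves the carbonyl attachment itself untouched, and no compound carrying a propoxy group has yet been measured in this assay. Going by the values given here, the expectation therefore rests on weak ground, namely that the two measured compounds lie close together and that the single recorded step was small. Compound 3 is expected to land near 58%, with a range from 35% to 80%, kept wide since nothing measured speaks directly to the exchange of allylamino for propoxy. For compound 3 this estimate means a step of a number 6 percentage points lower from compound 2 to compound 3 (within the scatter), not expected to reach beyond the scatter.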

Compound 3, percent growth inhibition at one concentration: 7%
Estimate against measurement, compound 3: 51 percentage points above, and the stated range ends above it.
By their numbers in this assay, from the lowest: compound 3; then compounds 2 and 1 (each within the scatter of the next).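

In this assay the carbonyl carbon proves to be a place where the attached group matters: propoxy in place of allylamino gives a number 57 percentage points lower from compound 2 to compound 3 (beyond the scatter) and propoxy in place of (tert-butyl)amino gives a number 66 percentage points lower from compound 1 to compound 3 (beyond the scatter) while the earlier exchange on the amide-type nitrogen stayed within the scatter. Growth inhibition at the one concentration tested is thus largely kept across the two amino groups shown and largely lost with propoxy, in an exchange that leaves the heavy-atom count of the group unchanged and takes away its hydrogen-bond donor. Nothing measured on these compounds accounts for the drop, which stands as an observation only.

With a single group attached through oxygen, the compounds shown do not tell whether the loss belongs to oxygen in place of nitrogen generally or to propoxy in particular. A methoxy group, a longer alkoxy chain, a free carboxylic acid and a propylamino group on the same carbonyl carbon would each bear on that question, the last by pairing directly with propoxy.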